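The compounds below may be only part of what the source reports. "The series", "measured", "known", "first", "only" and "open" are said of these compounds alone.

Measured in a functional assay on NCI-H460 cells (Homo sapiens) for cytotoxicity, read by sulforhodamine B assay, with a stated time of 3 days; a higher number here means a weaker inhibitor, a lower number a stronger inhibitor:
- Compound 1 `CC(O)c1cn(Cc2ccc(Cl)cc2)c2ccccc12`: 25100 nM
- Compound 2 `Cc1cn(Cc2ccc(Cl)cc2)c2ccccc12`: > 31600 nM

The reading for compound 2, > 31600 nM, is a limit of the assay and not a number, so compound 2 has no exact position in the series. Compound 3 `COC(=O)CNCc1cn(Cc2ccc(Cl)cc2)c2ccccc12` differs from it by ((methoxycarbonyl)methyl)amino in place of hydrogen on a saturated chain carbon bound to an aromatic carbon. Among the compounds with values here, only one measured step bears on this change: an at least 1.2-fold higher number from compound 1 to compound 2 (0.10 log units; that floor lies within the scatter). That step also alters the group on the same aromatic carbon, but it is bounded on one side only and involves a different group. Within the data shown here, no step clearly beyond the scatter is therefore expected in this assay, with a slight lean towards a lower number. The lean rests on compound 1, which gives a measurable 25100 nM. The expected change is an at least 1.7-fold lower number from compound 2 to compound 3 (0.24 log units; that floor lies within the scatter). For compound 3 the estimated value is 18000 nM, with an expected range of 5000 nM to 31600 nM.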

Compound 3, half-maximal inhibitory concentration: 100 nM
Beside the measured number, compound 3's estimate is 180-fold (2.26 log units) above it; measured number outside the range, below it.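

In this assay, within the data shown here, the saturated chain carbon bound to an aromatic carbon is the first place where a change clearly moves the reading: ((methoxycarbonyl)methyl)amino in place of hydrogen there gives an at least 310-fold lower number from compound 2 to compound 3 (2.49 log units; beyond the scatter). The comparison with the measurable compound gives a 250-fold lower number from compound 1 to compound 3 (2.40 log units; beyond the scatter), so the large size of the change does not depend on a limit alone. The step from compound 2 is only a floor, as compound 2 carries a limit of the assay and not a number: the limit of > 31600 nM in this assay, at which 1 of the 3 values shown sits.

The compounds shown leave open whether the step follows from the amine alone, as in a simple methylamino group, or needs the ester, for which the free carboxylic acid would be the direct comparison. On these data alone, whether a longer chain in the entering group keeps the step also stays open.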